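This account rests on a few compounds, and the source may have more. Where it says the series, first, only, none or still open, it means among the compounds named here.

Measured in an ADME assay on HEK-293T cells (Homo sapiens) for cytotoxicity, read by MTT assay, with a stated time of 48 h; on this read-out lower numbers stand for higher toxicity in this test and higher numbers for lower toxicity in this test:
- Compound 1 `COc1ccc2c(c1)c(C1CC(c3ccc(F)cc3)=NN1C(=O)c1ccc(OC)nc1)cn2C`: > 300000 nM
- Compound 2 `COc1ccc2c(c1)c(C1CC(c3ccc(Cl)cc3)=NN1C(=O)c1ccc(OC)nc1)cn2C`: > 300000 nM

Compound 2 stands at > 300000 nM, which is a limit of the assay and not a number. Compound 1, at > 300000 nM, also gives only a limit. The picture so far is therefore (the limit of > 300000 nM in this assay, at which 2 of the 2 values shown sit), and no numerical value has yet been obtained for either compound.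

Compound 3 `COc1ccc2c(c1)c(C1CC(c3ccc(Br)cc3)=NN1C(=O)c1ccc(OC)nc1)cn2C` keeps the shared core of compound 2 and has bromo in place of chloro on an aromatic carbon. The exchange lies on a six-membered aromatic ring of carbon only, para to a large group, and takes 4-chlorophenyl to 4-bromophenyl.

Among the measured compounds shown here, only one measured step bears on this change, chloro in place of fluoro on an aromatic carbon, and it reads as a step that the two limits leave unreadable from compound 1 to compound 2. It offers no size and no direction to carry over, so no shift beyond the scatter is expected in this assay. The estimated change is a number no higher from compound 2 to compound 3 (the limit leaves the size open). For compound 3 the expected value is 300000 nM, with an estimated range of 150000 nM to 500000 nM.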

Compound 3, half-maximal cytotoxic concentration: > 300000 nM
Compound 3: no number, only a limit; the forecaster's own chance of this, stated with the estimate: 85%; the middle value sits exactly at the limit.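

In this assay, among the compounds shown here, no step among compound 1, compound 2 and compound 3 can be read, as all three give only a limit and no number: the limit of > 300000 nM in this assay, at which 3 of the 3 values shown sit. The compounds shown leave open whether fluoro, chloro and bromo differ at all in this test, and at what concentration any of the three would show cytotoxicity.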